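Adding a Second Fluorine to a Triazole Aryl Ring

The compounds below may be only part of what the source reports. "The series", "measured", "known", "first", "only" and "open" are said of these compounds alone.

Three close relatives share one core and differ only in the ring attached to the aromatic nitrogen. Compound 1 `Cc1ccc(-n2nc(-c3ccc(C(F)(F)F)cc3O)nc2-c2ccccc2O)cc1` carries a 4-methylphenyl there, compound 2 `Oc1cc(C(F)(F)F)ccc1-c1nc(-c2ccccc2O)n(-c2ccc(I)cc2)n1` a 4-iodophenyl, and compound 3 `Oc1cc(C(F)(F)F)ccc1-c1nc(-c2ccccc2O)n(-c2cccc(F)c2)n1` a 3-fluorophenyl. In a functional assay on PC-12 cells (Rattus norvegicus) for cytotoxicity, read by MTT assay, with stated times of 2 h and 24 h, tested at 1 uM (a lower number here means a weaker effect, a higher number a stronger effect of the compound at the concentration tested), compound 1 gives 71.5%, compound 2 gives 70.1%, and compound 3 gives 67.2%. The steps are small: a number 1.4 percentage points lower from compound 1 to compound 2 (within the scatter), a number 4.3 percentage points lower from compound 1 to compound 3 (within the scatter) and a number 2.9 percentage points lower from compound 2 to compound 3 (within the scatter) all stay inside the scatter, so compound 3 cannot be told apart from the other two on these numbers.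

Compound 4 `Oc1cc(C(F)(F)F)ccc1-c1nc(-c2ccccc2O)n(-c2cc(F)cc(F)c2)n1` takes the same route one step further: fluoro in place of hydrogen on an aromatic carbon. Among the compounds with values here, no measured step covers exactly this change, but the three steps above show that swapping groups on this ring, even iodo for methyl, left this assay essentially unchanged. A second fluoro is therefore expected to do the same, with no step beyond the scatter.

Compound 4 is expected to give about 66%, with a likely range from 56% to 76%. This estimate amounts to an expected step of a number 1.2 percentage points lower from compound 3 to compound 4 (within the scatter), within the scatter.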

Compound 4, a percentage reported as activity, at one concentration (the size of the read-out at that concentration, not a potency): 75.5%
Compound 4: the middle estimate sits 9.5 percentage points below what was measured, and the stated range covers the measured number.
By their numbers in this assay, from the lowest: compounds 3, 2, 1 and 4 (each within the scatter of the next).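

In this assay, adding a second fluoro gives the largest step seen so far on this ring (a number 8.3 percentage points higher from compound 3 to compound 4 (within the scatter)), yet that step still stays inside the scatter. The 3,5-difluorophenyl ring also cannot be told apart from the 4-iodophenyl ring (a number 5.4 percentage points higher from compound 2 to compound 4 (within the scatter)) or the 4-methylphenyl ring (a number 4 percentage points higher from compound 1 to compound 4 (within the scatter)). So, at this position on the aromatic nitrogen, a ring with two fluoro groups joins the methyl, iodo and single fluoro rings as one more change that this read-out does not separate.

Still open, on these data alone, is whether a different kind of group on this ring, such as an amine or a carboxylic acid, would produce a step beyond the scatter. Nothing available explains the small differences among these four compounds.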